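Propylsulfonyl piperidine in place of the aryl group

The source may hold more compounds than are shown below. What is called first, only, known or untested is meant among the compounds shown, and "the series" means these compounds.

Measured so far:
compound 1 `CCCS(=O)(=O)N1CC=C(c2ccc3c(c2)CC(C2CCN(c4ncc(C(F)(F)F)cn4)CC2)O3)CC1`: 14 nM
compound 2 `CCCc1cnc(N2CCC(C3Cc4cc(-c5ccc(S(C)(=O)=O)cc5F)ccc4O3)CC2)nc1`: 541 nM

Two compounds of the series carry a value in a functional assay on HEK293 cells for agonist activity at Glucose-dependent insulinotropic receptor (Homo sapiens), read by cAMP accumulation, with a stated time of 60 min; on this read-out higher numbers stand for an effect only at larger amounts of compound and lower numbers for an effect already at smaller amounts. Compound 1 gives 14 nM in this assay. Compound 2 gives 541 nM in this assay, the higher of the two numbers, and the gap to compound 1 is stated to lie beyond the usual scatter. Within the data shown here, no pair of compounds differing in a single place has been measured, so no step size can be drawn from the numbers themselves.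

Compound 3 `CCCc1cnc(N2CCC(C3Cc4cc(C5CCN(S(=O)(=O)CCC)CC5)ccc4O3)CC2)nc1` is not yet measured. It differs from compound 2 in one place: 1-(propylsulfonyl)piperidin-4-yl in place of 2-fluoro-4-(methylsulfonyl)phenyl on an aromatic carbon. The entering group is the one that, in an unsaturated form, is carried by compound 1, while the remainder of compound 3 matches compound 2.

The expectation is a step downward from compound 2 to compound 3 of a 15-fold lower number from compound 2 to compound 3 (1.19 log units; beyond the scatter), beyond the scatter, because compound 1, which carries a closely related propylsulfonyl-bearing ring, gives 14 nM in this assay. The estimate for compound 3 in this assay is 35 nM, with a range from 8 nM to 150 nM.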

Compound 3, half-maximal effective concentration: 386 nM
For compound 3 the middle estimate is 11-fold (1.04 log units) below the measured one; the measured number lies above the stated range.
By their numbers in this assay, from the lowest: compound 1; then compounds 3 and 2 (each within the scatter of the next).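

Among these compounds, exchanging 2-fluoro-4-(methylsulfonyl)phenyl for 1-(propylsulfonyl)piperidin-4-yl on this aromatic carbon is the first single-place change, and in this assay it gives a step within the scatter (a 1.4-fold lower number from compound 2 to compound 3 (0.15 log units; within the scatter)). With everything else held fixed, the read-out at this position therefore does not separate a six-membered aromatic ring of carbon only from a six-membered non-aromatic ring with 1 hetero atom, when each carries a sulfonyl group. Nothing available bears on why the two groups read alike.

Compound 1, at 14 nM, differs from compound 3 in more than one place, both in the unsaturation of the ring carrying the propylsulfonyl group and in trifluoromethyl standing where compound 3 has propyl, so its value cannot be assigned to either difference. Also open, going by these compounds, is how a primary amine or a carboxylic acid on this same aromatic carbon would read in this assay, with the rest of compound 3 unchanged.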